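Pyridine Nitrogen Shift on a Piperazine-Linked Thiophene Ketone

The source may report more compounds than this note shows. Statements on the series, on what has been measured and on what is new or still open speak of the compounds shown alone.

Compound 2 `Nc1scc(CN2CCN(c3cccnc3)CC2)c1C(=O)c1ccc(Cl)cc1` gives 3.2% in a functional assay on CHO cells with adenosine receptor A1 (Homo sapiens) as the target, read by cAMP accumulation and immunoassay, with a stated time of 6 min, tested at 0.01 uM (on this read-out higher numbers stand for a weaker effect at the one concentration tested and lower numbers for a stronger effect), while compound 1 `Nc1scc(CN2CCN(c3ccc(Cl)c(C(F)(F)F)c3)CC2)c1C(=O)c1ccc(Cl)cc1` gives -2.5%; the two values lie within the scatter of each other, both close to no effect. Among the measured compounds shown here, the only measured step, a number 5.7 percentage points higher from compound 1 to compound 2 (within the scatter), replaced a much larger aryl group with pyridin-3-yl and produced no change beyond the scatter. Compound 3 `Nc1scc(CN2CCN(c3ccncc3)CC2)c1C(=O)c1ccc(Cl)cc1` differs from compound 2 by pyridin-4-yl in place of pyridin-3-yl on an amine nitrogen in a ring. For the measured compounds named here, no measured step repeats this exact change, so the account rests on compound 1 and compound 2 alone, both near zero. Since the earlier aryl replacement left the read-out unchanged, the expected step of a number 0.2 percentage points lower from compound 2 to compound 3 (within the scatter) is none beyond the scatter. Compound 3 is therefore expected to give about 3%, with a range from -8% to 14%.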

Compound 3, a percentage reported as activity, at one concentration (the size of the read-out at that concentration, not a potency): -4%
Compound 3: middle estimate off by 7 percentage points, on the high side, and the stated range covers the measured number.
By their numbers in this assay, from the lowest: compounds 3, 1 and 2 (each within the scatter of the next).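

In this assay, moving the ring nitrogen within the same pyridine group, with the same atoms joined differently, gives a number 7.2 percentage points lower from compound 2 to compound 3 (within the scatter), so this position on the amine nitrogen in a ring shows no response to where that nitrogen sits that can be told from the scatter. The pyridin-4-yl group also stands level with the much larger 4-chloro-3-(trifluoromethyl)phenyl group, with a number 1.5 percentage points lower from compound 1 to compound 3 (within the scatter), so neither of the two pyridine isomers can be separated from that aryl group on this read-out. No measurement given here bears on why these groups read alike.

On these data alone, it remains open whether a benzyl group, or a longer chain ending in a carboxylic acid, at this position would move the read-out beyond the scatter. The single tested concentration also leaves open whether these three compounds would differ at other concentrations.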